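Adding a Methoxy Group and Its Effect on Cell Tolerance

The compounds below may be only part of what the source reports. "The series", "measured", "known", "first", "only" and "open" are said of these compounds alone.

Compound 2 `COc1ccc(C(=O)Nc2ccc(Cl)cc2F)cc1` and compound 1 `COc1ccc(C(=O)Nc2ccc(Cl)cc2F)c(OC)c1` share a core and differ in one place: methoxy in place of hydrogen on an aromatic carbon. In an ADME assay on RAW264.7 cells (Mus musculus) for cytotoxicity, read by MTT assay, with a stated time of 24 h (a higher number here means that more compound is tolerated, a lower number that less compound is tolerated), compound 2 gives only a limit of the assay, > 40000 nM. In this assay compound 1 gives 13600 nM. The step is an at least 2.9-fold lower number from compound 2 to compound 1 (0.46 log units; beyond the scatter), so the added methoxy group left the cells tolerating less compound.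

Compound 3 `O=C(Nc1ccc(-c2ccc(F)cc2F)cc1F)c1ccccc1O` gives 28600 nM in this assay; how its core differs from that of compound 2 is not broken down here. Compound 4 `COc1ccc(C(=O)Nc2ccc(-c3ccc(F)cc3F)cc2F)c(O)c1` carries the same kind of change relative to compound 3: methoxy in place of hydrogen on an aromatic carbon. The surroundings differ, however: in compound 4 the methoxy group sits meta to a hydroxy group and para to a large group, whereas in compound 1 it sits ortho to a large group and meta to a methoxy group.

Resting on the step of an at least 2.9-fold lower number from compound 2 to compound 1 (0.46 log units; beyond the scatter), a similar lowering is expected for compound 4, namely a 2.4-fold lower number from compound 3 to compound 4 (0.38 log units; beyond the scatter). Compound 4 is therefore estimated at 12000 nM in this assay.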

Compound 4, half-maximal cytotoxic concentration: 26300 nM
The estimate for compound 4 lay 2.2-fold (0.34 log units) below the measured number, within the range that was stated.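

On the core of compound 3, the same swap of hydrogen for methoxy gives a 1.1-fold lower number from compound 3 to compound 4 (0.04 log units; within the scatter), so this assay does not separate these two compounds. The lowering seen on the first core therefore did not carry over to the second, and the two steps differ: the same change on two cores in this assay, an at least 2.9-fold lower number (0.46 log units; beyond the scatter) from compound 2 to compound 1 and a 1.1-fold lower number (0.04 log units; within the scatter) from compound 3 to compound 4, at least 2.7-fold (0.43 log units) apart, beyond the scatter of two such steps. Within the data shown here, with only two pairs, which also differ in what surrounds the methoxy group, this does not show whether the core or those surroundings decide the outcome, and it gives no rule for other cores.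

Still open, on these data alone, is whether an ethoxy group, an amine or a carboxylic acid at the same place would behave differently on the two cores. The compounds shown also leave open what part the hydroxy group of compound 4 plays in the contrast with compound 1.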